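The source may report more compounds than this note shows. Statements on the series, on what has been measured and on what is new or still open speak of the compounds shown alone.

In a functional assay on the whole organism (strain Kunming) with Mus musculus as the target, in the formalin test, with a stated time of 0.5 h (on this read-out higher numbers stand for an effect only at larger amounts of compound and lower numbers for an effect already at smaller amounts), the measured compounds read as follows:
- compound 1 `COc1ccccc1/C=C/C(=O)OC/C=C/c1cc(OC)c(OC)cc1OC` gives 113 mg/kg as a number
- compound 2 `COc1cc(OC)c(OC)cc1/C=C/COC(=O)/C=C/c1ccc(OC)c(OC)c1` gives 93.3 mg/kg as a number
- compound 3 `COc1cc(OC)c(OC)cc1/C=C/COC(=O)/C=C/c1c(OC)ccc(OC)c1OC` gives <= 80 mg/kg as a limit, not a number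

For the measured compounds named here, compound 2 cannot be told apart from compound 1, its only neighbour with a number, since a 1.2-fold lower number from compound 1 to compound 2 (0.08 log units; within the scatter) separates them. Going by the values given here, compound 3 is reported only as a limit and yields no step.

Compound 4 `COc1cc(OC)c(OC)cc1/C=C/COC(=O)/C=C/c1ccc(Br)cc1` differs from compound 2 at one place, on a double-bonded chain carbon bound to a double-bonded chain carbon, where 4-bromophenyl stands in place of 3,4-dimethoxyphenyl: 4-bromophenyl in place of 3,4-dimethoxyphenyl on a double-bonded chain carbon bound to a double-bonded chain carbon is the counted change.

Among the compounds with values here, one measured step bears on this place, namely a 1.2-fold lower number from compound 1 to compound 2 (0.08 log units; within the scatter) for 3,4-dimethoxyphenyl in place of 2-methoxyphenyl. Within the data shown here, it is a single step, and no bromine-bearing compound has a value yet, so the support is thin. On that step, no shift beyond the scatter is expected in this assay for this change.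

The expected step is a 1.0-fold lower number from compound 2 to compound 4 (0.02 log units; within the scatter) and no larger than the scatter.

For compound 4 the estimated value is 90 mg/kg with an expected range from 45 mg/kg to 175 mg/kg in this assay.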

Compound 4, dose for half-maximal effect: 105 mg/kg
For compound 4 the middle estimate is 1.2-fold (0.07 log units) below the measured one; the range from low to high includes it.
By their numbers in this assay, from the lowest: compounds 2, 4 and 1 (each within the scatter of the next). At a limit, below all of these: compound 3.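

In this assay, the place on a double-bonded chain carbon bound to a double-bonded chain carbon now carries a group with bromine instead of methoxy groups. The result is a 1.1-fold higher number from compound 2 to compound 4 (0.05 log units; within the scatter), and against the 2-methoxyphenyl compound it is a 1.1-fold lower number from compound 1 to compound 4 (0.03 log units; within the scatter). Compound 1 and compound 2 carried only methoxy-bearing phenyl groups here, whereas compound 4 shows that 4-bromophenyl, with no hydrogen-bond acceptors, cannot be told apart from either of them in this read-out.

From the compounds shown here alone, whether an amine or a carboxylic acid at this place would separate from these three compounds remains open. Compound 3 is reported only as a limit, so it gives no readable step at this place: the limit of <= 80 mg/kg in this assay, at which 1 of the 4 values shown sits.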